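Benzyloxycarbonyl in place of methyl on the shared core

This account rests on a few compounds, and the source may have more. Where it says the series, first, only, none or still open, it means among the compounds named here.

Values in a functional assay on MCF7 cells (Homo sapiens) for antiproliferative activity, read by MTT assay, with a stated time of 48 h (a higher number here means a weaker inhibitor, a lower number a stronger inhibitor), are:
Compound 1 `c1ccc(-c2nn(-c3ccccc3)cc2-c2nc3ccccc3[nH]2)cc1` gives 3190 nM
Compound 2 `Brc1ccc2[nH]c(-c3cn(-c4ccccc4)nc3-c3ccccc3)nc2c1` gives 830 nM
Compound 3 `Cc1ccc2[nH]c(-c3cn(-c4ccccc4)nc3-c3ccccc3)nc2c1` gives 5940 nM

Compound 3 lies within the scatter of compound 1 (a 1.9-fold higher number from compound 1 to compound 3 (0.27 log units; within the scatter)) and clearly apart from compound 2 (a 7.2-fold higher number from compound 2 to compound 3 (0.85 log units; beyond the scatter)). Within the data shown here, compound 4 `O=C(OCc1ccccc1)c1ccc2[nH]c(-c3cn(-c4ccccc4)nc3-c3ccccc3)nc2c1` carries benzyloxycarbonyl in place of methyl on an aromatic carbon and this group appears in no measured compound, so the range stays wide. Among the measured compounds shown here, two measured steps bear on it: a modest one for bromo (a 3.8-fold lower number from compound 1 to compound 2 (0.58 log units; beyond the scatter)) and one within the scatter for methyl (a 1.9-fold higher number from compound 1 to compound 3 (0.27 log units; within the scatter)). The lean towards a lower number rests on compound 2 (830 nM) alone. A modest step is expected, estimated as a 3.0-fold lower number from compound 3 to compound 4 (0.47 log units; beyond the scatter) in this assay overall. Estimated for compound 4 is 2000 nM with 500 nM to 7000 nM as the expected range.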

Compound 4, half-maximal inhibitory concentration: 12600 nM
For compound 4 the middle estimate is 6.3-fold (0.80 log units) below the measured one; the measured number lies above the stated range.
By their numbers in this assay, from the lowest: compound 2; then compounds 1 and 3 (each within the scatter of the next); then compound 4.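

In this assay, benzyloxycarbonyl on this aromatic carbon gives the highest number of the four compounds, with a 2.1-fold higher number from compound 3 to compound 4 (0.33 log units; beyond the scatter), a 3.9-fold higher number from compound 1 to compound 4 (0.60 log units; beyond the scatter) and a 15-fold higher number from compound 2 to compound 4 (1.18 log units; beyond the scatter). Bromo and benzyloxycarbonyl therefore move the number in opposite directions from compound 1, so this position does respond to the group it carries. No measured evidence accounts for this difference.

Going by these compounds, whether the higher number follows the carbonyl or the added aromatic ring remains open. Also open, on these data alone, is how a carboxylic acid or an amine at this carbon would compare.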